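Swapping an Ethyl for a Fluorophenyl on the Ring Nitrogen

The source may hold more compounds than are shown below. What is called first, only, known or untested is meant among the compounds shown, and "the series" means these compounds.

Of the compounds shown here, three have been measured in a functional assay on HOS cells (Homo sapiens) for inhibition, read by CCK-8 assay, with a stated time of 72 h, tested at 1 uM; a higher number here means more inhibition at the concentration tested (going by the name of the read-out), a lower number less inhibition. Compound 1 `COc1ccc(OC)c(N2C(=O)CSC2c2cccc(C(=O)NCCCCc3ccccc3)c2)c1` gives 5%. Compound 2 `CCN1C(=O)CSC1c1cccc(C(=O)NCCCCc2ccccc2)c1` gives 6%, and compound 3 `O=C(NCCCCc1ccccc1)c1cccc(C2OCC(=O)N2c2cccc(F)c2)c1` gives 29%. Compound 2 stands second highest of the three numbers; its nearest neighbour is compound 1, within the scatter, while compound 3 lies furthest away, beyond the scatter.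

The next compound, compound 4 `O=C(NCCCCc1ccccc1)c1cccc(C2SCC(=O)N2c2ccccc2F)c1`, is compound 2 with one change: 2-fluorophenyl in place of ethyl on an amide-type nitrogen in a ring. Going by the values given here, only one measured step bears directly on this change, the one in which ethyl replaced 2,5-dimethoxyphenyl on the same ring nitrogen: a number 1 percentage points higher from compound 1 to compound 2 (within the scatter). That step was flat, so an aryl group in place of ethyl at this position did not by itself move the number. Among the compounds with values here, compound 3 carries a fluorophenyl on its ring nitrogen and gives the highest value, but it differs from compound 2 in more than one place, so no single step connects them and its higher number cannot be assigned to the fluorophenyl alone.

The expected step from compound 2 to compound 4 is therefore small, if anything a modest rise, as a number 6 percentage points higher from compound 2 to compound 4 (within the scatter). Compound 4 is estimated at 12%, with a range from 2% to 28%.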

Compound 4, a percentage reported as inhibition, at one concentration (the size of the read-out at that concentration, not a potency): 83%
Beside the measured number, compound 4's estimate is 71 percentage points below it, outside the stated range (above it).
By their numbers in this assay, from the lowest: compounds 1 and 2 (each within the scatter of the next); then compound 3; then compound 4.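

In this assay, going by these compounds alone, the step from ethyl to 2-fluorophenyl on the amide-type nitrogen in the ring is a number 77 percentage points higher from compound 2 to compound 4 (beyond the scatter), so this position can move the read-out a long way, something the flat step among the earlier compounds gave no sign of. The step of a number 78 percentage points higher from compound 1 to compound 4 (beyond the scatter) adds a second point: 2,5-dimethoxyphenyl also brings a six-membered aromatic ring of carbon only, yet it stays within the scatter of ethyl, so an aromatic ring at this position does not by itself give the high number, and what the ring carries matters. Nothing available here explains why these two aryl groups part so sharply.

The compounds shown leave open whether the fluorine is needed at all, and a plain phenyl ring, or a chlorine or a methyl group in place of the fluorine on the same ring, would help to settle that. Each number is also a reading at a single concentration and not a potency, so how potent compound 4 is remains an open question.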